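Chloromethyl in Place of Isopropyl: What Compound 3 May Show

The source may report more compounds than this note shows. Statements on the series, on what has been measured and on what is new or still open speak of the compounds shown alone.

Compound 1 `CCC(=O)Nc1ccc(S(=O)(=O)Oc2ccccc2C(C)C)cc1` gives 11000 nM in a functional assay on MCF7 cells (Homo sapiens) for antiproliferative activity, read by sulforhodamine B assay, with a stated time of 48 h; on this read-out lower numbers stand for stronger inhibition and higher numbers for weaker inhibition. Compound 2 `CC(C)C(=O)Nc1ccc(S(=O)(=O)Oc2ccccc2C(C)C)cc1` gives 8600 nM in this assay, the smaller of the two numbers, although the step of a 1.3-fold lower number from compound 1 to compound 2 (0.11 log units; within the scatter) stays within the scatter. Compound 3 `CC(C)c1ccccc1OS(=O)(=O)c1ccc(NC(=O)CCl)cc1` differs from compound 2 by chloromethyl in place of isopropyl on a carbonyl carbon. For the measured compounds named here, the only measured step, a 1.3-fold lower number from compound 1 to compound 2 (0.11 log units; within the scatter), touched the same carbonyl-bound chain and barely moved the number, so it bears only loosely on this larger exchange. No shift beyond the scatter is therefore expected in this assay. For compound 3 the estimate is 7000 nM, expected to fall between 2000 nM and 25000 nM. This expected change amounts to a 1.2-fold lower number from compound 2 to compound 3 (0.09 log units; within the scatter).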

Compound 3, half-maximal inhibitory concentration: 2900 nM
Compound 3: the middle estimate sits 2.4-fold (0.38 log units) above what was measured; the measured number falls inside the stated range.
By their numbers in this assay, from the lowest: compound 3; then compounds 2 and 1 (each within the scatter of the next).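

In this assay chloromethyl in place of isopropyl on the carbonyl carbon brings a 3.0-fold lower number from compound 2 to compound 3 (0.47 log units; beyond the scatter) and chloro in place of methyl on the chain carbon brings a 3.8-fold lower number from compound 1 to compound 3 (0.58 log units; beyond the scatter) so this position can move the number beyond the scatter, which the earlier step did not show. Nothing at hand explains why the chloro-bearing chain gives the lower number. As far as these compounds go, it remains open whether chlorine itself matters, or whether another group on the same carbon, such as bromomethyl or aminomethyl, would give a similar number.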